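A thiophene swap at a solubility limit

The source may hold more compounds than are shown below. What is called first, only, known or untested is meant among the compounds shown, and "the series" means these compounds.

In a physicochemical assay for solubility, in phosphate buffer, at pH 6.8 (on this read-out higher numbers stand for higher solubility and lower numbers for lower solubility), compound 1 `CC(C)(C)C(=O)C1=C(O)C(=O)N(c2ccc(-c3ccon3)cc2)C1c1ccccc1OCCO` gives > 50000 nM as a limit and not a number. Sharing the core of compound 1, compound 2 `Cc1noc(-c2ccc(N3C(=O)C(O)=C(C(=O)C(C)(C)C)C3c3ccccc3OCCO)cc2)n1` gives > 50000 nM as a limit as well, so it has no number of its own in this assay to start from. All that is known so far is the limit of > 50000 nM in this assay, at which 2 of the 2 values shown sit, and nothing finer. For the measured compounds named here, the only measured step, a step that the two limits leave unreadable from compound 1 to compound 2, has no size to carry forward.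

Compound 3 `CC(C)(C)C(=O)C1=C(O)C(=O)N(c2ccc(-c3ccsc3)cc2)C1c1ccccc1OCCO` changes the same place, and the difference is thiophen-3-yl in place of 3-methyl-1,2,4-oxadiazol-5-yl on an aromatic carbon on an aromatic carbon of a six-membered aromatic ring of carbon only, para to a large group. Going by the values given here, no measured step shows what this change does in this assay and the expectation is therefore a cautious one. With compound 2 given only as > 50000 nM a moderate downward step is expected, with a real chance that the result is again only a limit. The expected step is an at least 1.6-fold lower number from compound 2 to compound 3 (0.22 log units; that floor lies within the scatter) as an estimate only. Compound 3 is estimated at 30000 nM with an expected range from 8000 nM to 80000 nM in this measurement.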

Compound 3, solubility: > 50000 nM
Compound 3: no number, only a limit; the forecaster's own chance of this, stated with the estimate: 45%; middle value at least 1.6-fold (0.22 log units) from the limit.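

In this assay compound 3 gives > 50000 nM, a limit and not a number. For the compounds shown here, no step among compound 1, compound 2 and compound 3 can be read. The compounds shown leave open how these three compare in this assay, and whether exchanging the aromatic groups changes the read-out at all, as all that is known is this: the limit of > 50000 nM in this assay, at which 3 of the 3 values shown sit.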